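Trifluoromethyl for chloro: working notes on compound 3

A few compounds are considered here, and "the series" means these few. Any claim that something is new, unique, unknown or untested is made for them only; others in the source may bear on it.

In a functional assay on K562 cells (Homo sapiens) for cytotoxicity, read by MTT assay, with a stated time of 24 h (a lower number here means a stronger inhibitor, a higher number a weaker inhibitor), compound 1 (`CN1C/C(=C\c2ccc(F)cc2)C(=O)/C(=C/c2ccc(C#N)cc2)C1`) gives 11300 nM and compound 2 (`CN1C/C(=C\c2ccc(Cl)cc2)C(=O)/C(=C/c2ccc(C#N)cc2)C1`) gives 13300 nM with the two standing level, within the scatter of each other. Compound 3 (`CN1C/C(=C\c2ccc(C#N)cc2)C(=O)/C(=C/c2ccc(C(F)(F)F)cc2)C1`) has not yet been measured. It differs from compound 2 by trifluoromethyl in place of chloro on an aromatic carbon, para to a large group.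

Within the data shown here, the only measured step that bears on this change is a 1.2-fold higher number from compound 1 to compound 2 (0.07 log units; within the scatter) and it is chloro in place of fluoro on an aromatic carbon. That single step stays within the scatter. Neither measured compound carries trifluoromethyl at the changing place, so the data leave the direction of any shift open. With compound 2 at 13300 nM as the anchor, no step beyond the scatter is expected in this assay for this change. The estimated move is a 1.0-fold lower number from compound 2 to compound 3 (0.01 log units; within the scatter) and it is expected to lie within the scatter. Compound 3 is expected near 13000 nM with an estimated range from 6500 nM to 26000 nM as the working figure.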

Compound 3, half-maximal inhibitory concentration: 4010 nM
Compound 3: the middle estimate sits 3.2-fold (0.51 log units) above what was measured; the measured number lies below the stated range.
By their numbers in this assay, from the lowest: compound 3; then compounds 1 and 2 (each within the scatter of the next).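

Among these compounds, the place on an aromatic carbon, para to a large group, is not indifferent to its substituent in this assay: the only earlier step, a 1.2-fold higher number from compound 1 to compound 2 (0.07 log units; within the scatter), gave no readable change, whereas trifluoromethyl gives a 3.3-fold lower number from compound 2 to compound 3 (0.52 log units; beyond the scatter) and, against the fluoro compound, a 2.8-fold lower number from compound 1 to compound 3 (0.45 log units; beyond the scatter). Both new steps are modest, but they separate compound 3 from compounds 1 and 2, which stand level with each other, so the series now holds a substituent change at this place that can be read beyond the scatter. No data at hand bear on what underlies this shift.

The compounds shown leave open how an amine, a carboxylic acid or a longer chain at this place would stand against trifluoromethyl, and therefore whether the lower number is particular to trifluoromethyl or extends to other groups. They also leave open whether the same exchange would give a step of similar size if the nitrile on the other aromatic ring were replaced by another group, such as an amine.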